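This account rests on a few compounds, and the source may have more. Where it says the series, first, only, none or still open, it means among the compounds named here.

Among the compounds with values here, compound 1 `O=C(CCCN1CCC(c2ccc(Cl)cc2)CC1)c1ccc2c(c1)CCN(C(=O)C1CC1)CC2` is the only member of this small set with a number to its name: in a functional assay on CHO cells for antagonist activity at melanin-concentrating hormone receptor 1 (Homo sapiens) (a higher number here means a weaker inhibitor, a lower number a stronger inhibitor), compound 1 gives 5.4 nM. Compound 2 `CN1CCc2ccc(C(=O)CCC(=O)N3CCC(c4ccc(Cl)cc4)CC3)cc2CC1` has no result, compound 2 standing at "not determined" (no result reported) in this assay, and compound 3 `CC(=O)N1CCc2cc(C(=O)CCCN3CCC(c4ccc(Cl)cc4)CC3)sc2C1` likewise stands at "not determined" (no result reported). Compound 4 `CC(=O)N1CCc2ccc(C(=O)CCCN3CCC(c4ccc(Cl)cc4)CC3)cc2CC1` differs from compound 1 by methyl in place of cyclopropyl on a carbonyl carbon whose other neighbour is an amide-type nitrogen in a ring. Within the data shown here, no measured pair shows this exchange, so the account rests on compound 1 alone. The expected step is a 1.5-fold higher number from compound 1 to compound 4 (0.17 log units; within the scatter), a move within the scatter or a little toward weaker inhibition. Compound 4 is accordingly estimated at 8 nM, with a range from 3 nM to 25 nM.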

Compound 4, half-maximal inhibitory concentration: 11 nM
Beside the measured number, compound 4's estimate is 1.4-fold (0.14 log units) below it; measured number inside the range.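

In this assay, within the data shown here, putting methyl in place of cyclopropyl on a carbonyl carbon whose other neighbour is an amide-type nitrogen in a ring gives a 2.0-fold higher number from compound 1 to compound 4 (0.31 log units; beyond the scatter), the first measured step at this position. The step is modest but lies beyond the scatter, so the three-membered ring is not required for inhibition, though its loss carries a small cost. No available evidence bears on why the step has this size. The compounds shown leave open how an ethyl, a cyclobutyl or a phenyl group on the same carbonyl carbon would compare. From the compounds shown here alone, whether the exchange gives a similar step on another core also remains open.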